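Adding a Methoxy Group to Compound 1

A few compounds are considered here, and "the series" means these few. Any claim that something is new, unique, unknown or untested is made for them only; others in the source may bear on it.

Compound 1 `COc1ccc(C(=O)/C=C/c2cc(-c3cc(OC)c(OC)c(OC)c3)n[nH]2)cc1OC` is the lower of the two compounds measured in a functional assay on NCI-H522 cells (Homo sapiens) for cytotoxicity, read by sulforhodamine B assay, with a stated time of 48 h, tested at 1 uM (a lower number here means a stronger effect, a higher number a weaker effect of the compound at the concentration tested), where compound 1 gives -63%. Among the measured compounds shown here, its only neighbour, compound 2 `COc1ccc(C(=O)/C=C/c2cc(-c3cc(OC)c(OC)c(OC)c3)n[nH]2)cc1`, gives 75%; the single measured step, a number 138 percentage points higher from compound 1 to compound 2 (beyond the scatter), came with hydrogen in place of methoxy on an aromatic carbon. Compound 3 `COc1cc(C(=O)/C=C/c2cc(-c3cc(OC)c(OC)c(OC)c3)n[nH]2)cc(OC)c1OC` moves the other way from compound 1: methoxy in place of hydrogen on an aromatic carbon. For the measured compounds named here, the one step on record bears on this only loosely, since it removed a methoxy group rather than adding one, yet it shows that the number of methoxy groups on that aromatic ring can shift the read-out by a large amount. With compound 1 already strongly active, the author expects compound 3 to keep a comparable read-out, with a number 8 percentage points higher from compound 1 to compound 3 (within the scatter) expected to stay small or within the scatter. Compound 3 is therefore estimated at -55%, with a range from -90% to 10%.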

Compound 3, a percentage reported as activity, at one concentration (the size of the read-out at that concentration, not a potency): 29%
Compound 3: middle estimate off by 84 percentage points, on the low side; measured number above the stated range.
By their numbers in this assay, from the lowest: compound 1; then compound 3; then compound 2.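

Methoxy in place of hydrogen at this carbon, ortho to a methoxy group and meta to a large group, is not a neutral addition in this assay: it gave a number 92 percentage points higher from compound 1 to compound 3 (beyond the scatter). Together with the earlier step, a number 138 percentage points higher from compound 1 to compound 2 (beyond the scatter), this shows that both removing and adding a methoxy group on this ring raised the number, leaving compound 1 the lowest of the three. Nothing at hand explains why either change had this effect.

The compounds shown leave open whether a smaller or different group at this carbon, such as a hydroxyl or a fluorine atom, would keep the number of compound 1 or raise it as methoxy did. They also leave open how a longer chain, such as ethoxy, would behave there.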